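Replacing Benzyloxy with a Small Alcohol: Expected Binding

The compounds below may be only part of what the source reports. "The series", "measured", "known", "first", "only" and "open" are said of these compounds alone.

Compound 1 `Brc1ccc2ccn(CCN3CCN4CCCCC4C3)c2c1`: 78%
Compound 2 `CN1CCCN(CCn2ccc3ccc(OCc4ccccc4)cc32)CC1`: 28%

Of the compounds shown here, two have been measured in an assay on HEK293 cells for binding affinity to 5-hydroxytryptamine receptor 7 (Homo sapiens), read by radioligand binding, tested at 1 uM; on this read-out lower numbers stand for less inhibition and higher numbers for more inhibition at the one concentration tested (going by the name of the read-out). Compound 1 gives 78%, while compound 2 gives 28%, the lower of the two numbers and a gap beyond the scatter. Among the measured compounds shown here, the two differ in several places at once, so no single step between them can be named.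

Compound 3 `CN1CCCN(CCn2ccc3ccc(C(C)(C)O)cc32)CC1` has not yet been measured. It differs from compound 2 in one place: 1-hydroxy-1-methylethyl in place of benzyloxy on an aromatic carbon. For the measured compounds named here, no measured pair shows what this kind of exchange does, so the expectation rests on compound 2 alone. A step of modest size is expected, if any, and it is not clear in which direction; the most likely outcome is a change no larger than the scatter, expected as a number 3 percentage points lower from compound 2 to compound 3 (within the scatter). Compound 3 is therefore estimated to give 25%, within a range of 5% to 50%.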

Compound 3, a percentage reported as inhibition, at one concentration (the size of the read-out at that concentration, not a potency): 6%
Beside the measured number, compound 3's estimate is 19 percentage points above it, within the range that was stated.
By their numbers in this assay, from the lowest: compound 3; then compound 2; then compound 1.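

Among the compounds shown here, this is the first step that can be read at this place on the aromatic ring: in this assay, 1-hydroxy-1-methylethyl in place of benzyloxy gives a number 22 percentage points lower from compound 2 to compound 3 (beyond the scatter). The position is therefore not indifferent to what it carries, at least for this exchange, which loses a six-membered aromatic ring and heavy atoms and gains a hydrogen-bond donor. All of these differences arrive in one step, so it cannot tell them apart, and nothing measured here explains the drop.

Still open, going by these compounds, is how methoxy, which keeps an oxygen on the ring carbon without a second ring, or phenyl, which keeps a ring without the oxygen, would read at this place. Either group would help show which part of benzyloxy goes with the higher number.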